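The compounds below may be only part of what the source reports. "The series", "measured", "known", "first", "only" and "open" are said of these compounds alone.

In an ADME assay on HCT-116 cells (Homo sapiens) for cytotoxicity, read by CellTiter-Glo, with a stated time of 72 h (a lower number here means a stronger inhibitor, a higher number a weaker inhibitor), compound 1 `Cc1cc(C)c(S(=O)(=O)N2CCC(N3CCC(c4ccccc4)CC3)CC2)c(C)c1` gives > 5000 nM, which is a limit and not a number. Compound 2 `Cc1cc(C)c(S(=O)(=O)N2CCC(N3CCC(Cc4ccc(F)cc4)CC3)CC2)c(C)c1` gives > 5000 nM, again a limit. Compound 3 `Cc1cc(C)c(S(=O)(=O)N2CCC(N3CCC(C(C)C)CC3)CC2)c(C)c1` gives > 5000 nM, also a limit. The three together: the limit of > 5000 nM in this assay, at which 3 of the 3 values shown sit. Compound 3 therefore offers no number to start from.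

Compound 4 `C#CCCC(=O)CC1CCN(C2CCN(S(=O)(=O)c3c(C)cc(C)cc3C)CC2)CC1` differs from compound 3 as follows: ((but-3-yn-1-yl)carbonyl)methyl in place of isopropyl on a saturated ring carbon. In words, ((but-3-yn-1-yl)carbonyl)methyl stands in place of isopropyl on a saturated ring carbon.

The measured steps at this place are a step that the two limits leave unreadable from compound 1 to compound 2, a step that the two limits leave unreadable from compound 1 to compound 3 and a step that the two limits leave unreadable from compound 2 to compound 3. None gives a size or a direction. In this assay, no step beyond the scatter is expected, so the expected step is a step that the limit leaves unreadable from compound 3 to compound 4. The estimate for compound 4 is 7000 nM, with an expected range of 2500 nM to 20000 nM.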

Compound 4, half-maximal inhibitory concentration: > 5000 nM
Compound 4 gave a limit, no number; the forecaster's own chance of this, stated with the estimate: 85%; the middle value is on the limit's open side.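

The steps from compound 1, compound 2 and compound 3 to compound 4 cannot be read, because all four values are limits and not numbers: the limit of > 5000 nM in this assay, at which 4 of the 4 values shown sit.

The compounds shown leave open whether any group at this place changes the value in this assay, and by how much.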